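A few compounds are considered here, and "the series" means these few. Any claim that something is new, unique, unknown or untested is made for them only; others in the source may bear on it.

Values in a toxicity assay on NIH3T3 cells (Mus musculus) for cytotoxicity, read by resazurin assay (a lower number here means that less compound is needed, a higher number that more compound is needed for the effect), each one a limit:

- Compound 1 `Cc1cccc(-c2cccc(NCc3cncn3Cc3ccccc3)c2)c1C`: > 1000 nM
- Compound 2 `Cc1ccccc1-c1cccc(NCc2cncn2Cc2ccccc2)c1`: > 1000 nM
- Compound 3 `c1ccc(Cn2cncc2CNc2cccc(-c3ccccc3)c2)cc1`: > 750 nM

Compound 3 has only a limit, as do the other two compounds, so it holds no rank in the series. Compound 4 `CC(C)c1cccc(NCc2cncn2Cc2ccccc2)c1` differs from compound 3 as follows: isopropyl in place of phenyl on an aromatic carbon. It carries isopropyl in place of phenyl on an aromatic carbon, meta to a large group. The measured steps nearest this change are a step that the two limits leave unreadable from compound 1 to compound 3 and a step that the two limits leave unreadable from compound 2 to compound 3, and neither has a readable size. No shift beyond the usual scatter is therefore expected in this assay, in either direction. The expected step is a step that the limit leaves unreadable from compound 3 to compound 4. For compound 4 the estimated value is 1500 nM, with an expected range from 700 nM to 4000 nM.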

Compound 4, half-maximal effective concentration: > 1000 nM
Compound 4: no number, only a limit (the forecaster's own chance of this, stated with the estimate: 80%); the middle value is on the limit's open side.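

In this assay, going by these compounds alone, compound 4 gives only a limit, as do compounds 1, 2 and 3, so no step among the four can be read. The compounds shown leave open where any true value lies, and whether isopropyl, phenyl, 2-methylphenyl and 2,3-dimethylphenyl differ at all.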